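From tert-Butyl to Methyl in PC-3 Growth Inhibition

This account rests on a few compounds, and the source may have more. Where it says the series, first, only, none or still open, it means among the compounds named here.

The measured compounds and their values:
compound 1, `O=C(CCC1=CCN(CCCc2ccc(Cl)cc2)C1=O)NO`, 3480 nM
compound 2, `CC(C)(C)c1ccc(CCCN2CC=C(CCC(=O)NO)C2=O)cc1`, 3480 nM

Both measurements come from a functional assay on PC-3 cells (Homo sapiens) for inhibition, read by sulforhodamine B assay; a lower number here means a stronger inhibitor of growth, a higher number a weaker inhibitor of growth. Compound 2 stands level with compound 1, its nearest neighbour, since the step of no change at the digits printed from compound 1 to compound 2 (within the scatter) stayed within the scatter although a tert-butyl took the place of a chloro on an aromatic carbon.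

Compound 3, `Cc1ccc(CCCN2CC=C(CCC(=O)NO)C2=O)cc1`, is the next member and has not yet been measured. It differs from compound 2 in one place: methyl in place of tert-butyl on an aromatic carbon.

For the measured compounds named here, only one measured step bears on this change, and it is the one just described: the exchange of chloro for tert-butyl at the same position moved this assay by nothing beyond the scatter. Two groups that differ greatly in size gave the same reading, so a further shrinking from tert-butyl to methyl is not expected to register either; the estimated step of a 1.0-fold higher number from compound 2 to compound 3 (0.00 log units; within the scatter) is therefore expected to stay within the scatter.

On that basis compound 3 is expected to give about 3500 nM in this assay, with a likely range from 1500 nM to 8000 nM.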

Compound 3, concentration for 50% growth inhibition: 3480 nM
Estimate against measurement, compound 3: 1.0-fold (0.00 log units) above, within the range that was stated.
By their numbers in this assay, from the lowest: compounds 1, 2 and 3 (each within the scatter of the next).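

In this assay the exchange of tert-butyl, with 4 heavy atoms, for methyl, with 1 heavy atom, gave no change at the digits printed from compound 2 to compound 3 (within the scatter) and so extended the flat reading to a much smaller carbon group at this position. For the compounds shown here, the exchange of chloro for methyl at the same aromatic carbon, para to a large group, likewise gave no change at the digits printed from compound 1 to compound 3 (within the scatter) as its result, so chloro, tert-butyl and methyl now form a set of three groups that this assay does not separate, where the earlier compounds offered only one pair. No measurement is available that would explain why the reading stays the same across these three groups.

The compounds shown carry only carbon groups or chloro at this position, so they leave open whether an amine, a carboxylic acid or a plain hydrogen there would also give the same reading in this assay as well. They also leave open whether the same flat reading would hold with a longer chain joining the aromatic ring to the shared core, or with the ring itself exchanged for a pyridine.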